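A Triazole Sulfur Group in Place of Acetoxy

The compounds below may be only part of what the source reports. "The series", "measured", "known", "first", "only" and "open" are said of these compounds alone.

Of the compounds shown here, two have been measured. In a functional assay on T47D cells (Homo sapiens) for antiproliferative activity, read by sulforhodamine B assay, with a stated time of 48 h (a lower number here means a stronger inhibitor of growth, a higher number a weaker inhibitor of growth), compound 2 `CC(=O)OC[C@H]1O[C@@H](OCc2noc(-c3ccc([N+](=O)[O-])cc3)n2)[C@@H]2OC3(CCCC3)O[C@@H]21` gives 52000 nM. Compound 1 `COc1cc(C2=NOC(CO[C@@H]3O[C@H](CSc4ncn[nH]4)[C@H]4OC5(CCCC5)O[C@@H]34)C2)cc(OC)c1OC` gives 55000 nM in this assay; the two numbers lie within the usual scatter of each other, so neither can be called the stronger inhibitor. Compound 3 `O=[N+]([O-])c1ccc(-c2nc(CO[C@@H]3O[C@H](CSc4ncn[nH]4)[C@H]4OC5(CCCC5)O[C@@H]34)no2)cc1` differs from compound 2 by (1H-1,2,4-triazol-5-yl)sulfanyl in place of acetoxy on a saturated chain carbon bound to a saturated ring carbon. Only a step within the scatter is expected because compound 1 already carries the entering group and gives 55000 nM in this assay. The expected step is a 1.0-fold lower number from compound 2 to compound 3 (0.02 log units; within the scatter). Compound 3 is therefore estimated to give 50000 nM, with a range from 20000 nM to 130000 nM.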

Compound 3, concentration for 50% growth inhibition: 20000 nM
Compound 3: the middle estimate sits 2.5-fold (0.40 log units) above what was measured, within the range that was stated.
By their numbers in this assay, from the lowest: compound 3; then compounds 2 and 1 (each within the scatter of the next).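

In this assay, (1H-1,2,4-triazol-5-yl)sulfanyl in place of acetoxy on a saturated chain carbon bound to a saturated ring carbon gives a 2.6-fold lower number from compound 2 to compound 3 (0.41 log units; beyond the scatter), so this position responds to the change, though modestly. Compound 1 carries the same group but differs from compound 2 in more than one place, and its value alone could not show this. Nothing measured here explains the step. On these data alone, whether the step follows the triazole ring or the sulfur alone stays open, and methylsulfanyl or an amine on the same carbon would bear on that.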